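Trimming the Amine Substituent in a Diaryl Ether Series

The compounds below may be only part of what the source reports. "The series", "measured", "known", "first", "only" and "open" are said of these compounds alone.

Compound 1 `COc1cc(Oc2cccc(Nc3ccccc3)c2)cc(OC)c1CNCc1ccc(F)cc1` is the stronger of the two measured compounds in a functional assay on DLD-1 cells (Homo sapiens) for inhibition, read by MTT assay, with a stated time of 72 h; a lower number here means a stronger inhibitor, a higher number a weaker inhibitor; in this assay compound 1 gives 2650 nM. Compound 2 `COc1cc(Oc2cccc(Nc3ccccc3)c2)cc(OC)c1CN[C@H](C)c1ccccc1` differs only at the amine nitrogen and gives 8570 nM in this assay, so that a 3.2-fold higher number from compound 1 to compound 2 (0.51 log units; beyond the scatter). Among the measured compounds shown here, compound 3 `COc1cc(Oc2cccc(Nc3ccccc3)c2)cc(OC)c1CN(C)C` has not been measured. dimethylamino in place of (4-fluorobenzyl)amino on a saturated chain carbon bound to an aromatic carbon Only the step between compound 1 and compound 2 speaks to this change, since it too alters the group on that nitrogen, and it showed a modest loss. A weaker result is therefore expected for compound 3 in this assay, because a 3.2-fold higher number from compound 1 to compound 2 (0.51 log units; beyond the scatter) already shows that altering this group costs potency, and the new group here is smaller still, with no ring. For compound 3 the expected value is 7000 nM, in a range from 2500 nM to 20000 nM, which corresponds to an expected step of a 2.6-fold higher number from compound 1 to compound 3 (0.42 log units; beyond the scatter).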

Compound 3, half-maximal inhibitory concentration: > 20000 nM
Compound 3 gave a limit, no number; the forecaster's own chance of this, stated with the estimate: 15%; middle value at least 2.8-fold (0.45 log units) from the limit.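

Compound 3 in this assay gives a limit of the assay rather than a number: the limit of > 20000 nM in this assay, at which 1 of the 3 values shown sits.

Even so, the limit is enough to order the change: dimethylamino in place of (4-fluorobenzyl)amino gives an at least 7.5-fold higher number from compound 1 to compound 3 (0.87 log units; beyond the scatter) and dimethylamino in place of (1-phenylethyl)amino gives an at least 2.3-fold higher number from compound 2 to compound 3 (0.36 log units; beyond the scatter). Among the compounds shown here, compound 1 and compound 2 showed only that swapping one ring-bearing group for another changes the number, whereas compound 3 shows that losing the ring altogether from this position, together with the hydrogen-bond donor counted for (4-fluorobenzyl)amino, costs more than the swap between the two ring-bearing groups did.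

The ring and the amine hydrogen leave together here, so the compounds shown cannot say which of them matters. A methylamino group, or an N-methylbenzylamino group, would separate the two.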